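Swapping one fluoro for methyl on the difluorophenyl ring

The source may report more compounds than this note shows. Statements on the series, on what has been measured and on what is new or still open speak of the compounds shown alone.

For the measured compounds named here, in a functional assay on A498 cells (Homo sapiens) for cytotoxicity (a lower number here means a stronger inhibitor of growth, a higher number a weaker inhibitor of growth), compound 2 (`CSc1ccc(C2=C(c3ccc(F)c(F)c3)C(=O)N3CCCC3C2)cc1`) gives 100 nM as the lower of the two numbers so far, and compound 1 (`COc1ccc(C2=C(c3ccc(SC)cc3)CC3CCCN3C2=O)cc1C`) gives 400 nM as the higher. Compound 3 (`CSc1ccc(C2=C(c3ccc(F)c(C)c3)C(=O)N3CCCC3C2)cc1`) differs from compound 2 by methyl in place of fluoro on an aromatic carbon at one place: methyl in place of fluoro on an aromatic carbon, which turns 3,4-difluorophenyl into 4-fluoro-3-methylphenyl. Going by the values given here, the only measured guide is a 4.0-fold lower number from compound 1 to compound 2 (0.60 log units; beyond the scatter) with 3,4-difluorophenyl in place of 4-methoxy-3-methylphenyl on the same ring carbon, and compound 3 regains a methyl as in compound 1 while keeping one fluoro, so only part of that step is expected to return, towards a higher number. The estimate therefore means a 1.6-fold higher number from compound 2 to compound 3 (0.20 log units; within the scatter) as the expected change, which may not exceed the scatter. For compound 3 the expected value is 160 nM with an estimated range from 60 nM to 400 nM in this assay.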

Compound 3, concentration for 50% growth inhibition: 300 nM
For compound 3 the middle estimate is 1.9-fold (0.27 log units) below the measured one, and the stated range covers the measured number.
By their numbers in this assay, from the lowest: compound 2; then compounds 3 and 1 (each within the scatter of the next).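

In this assay, for the compounds shown here, the single swap of methyl for fluoro on this aromatic carbon, ortho to a fluoro group, gives a 3.0-fold higher number from compound 2 to compound 3 (0.48 log units; beyond the scatter), so the carbon responds to this change on its own. The other new step, fluoro in place of methoxy with the methyl kept, gives a 1.3-fold lower number from compound 1 to compound 3 (0.12 log units; within the scatter), which lies within the scatter; of the earlier step between the 4-methoxy-3-methylphenyl and 3,4-difluorophenyl compounds, the methyl-to-fluoro change alone thus reproduces a step beyond the scatter, while the methoxy-to-fluoro change does not. Nothing available explains this difference between fluoro and methyl.

The compounds shown leave open how a chloro group, a hydroxyl or an amine on this carbon would compare with fluoro and methyl. They also leave open whether the same swap would give a similar step with the methylthio group on the other phenyl ring replaced.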